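The source may hold more compounds than are shown below. What is called first, only, known or untested is meant among the compounds shown, and "the series" means these compounds.

Compound 1, `CNC(=O)CCc1ccncc1-c1ccc2ccccc2c1`, gives 10400 nM in a functional assay on A549 cells (Homo sapiens) for inhibition, read by sulforhodamine B assay, with a stated time of 72 h; a higher number here means a weaker inhibitor of growth, a lower number a stronger inhibitor of growth.
Compound 2, `O=C(O)CCc1ccncc1-c1ccc2ccccc2c1`, reaches only a limit of this assay, > 10000 nM.
Compound 3, `COC(=O)/C=C/c1ccncc1-c1ccc2ccccc2c1`, gives 760 nM.

Compound 2 therefore stands at the weak end of the three, known only as a limit and not as a number, a point recorded as the limit of > 10000 nM in this assay, at which 1 of the 3 values shown sits. Compound 4, `O=C(CCc1ccncc1-c1ccc2ccccc2c1)N1CCOCC1`, differs from it by morpholin-4-yl in place of hydroxy on a carbonyl carbon. The nearest measured step is a step that the limit leaves unreadable from compound 1 to compound 2, which the limit leaves unreadable, so the shift from an amide to the acid is of unknown size here. The steps of a 14-fold lower number from compound 1 to compound 3 (1.14 log units; beyond the scatter) and an at least 13-fold lower number from compound 2 to compound 3 (1.11 log units; beyond the scatter) are large, but both involve the ester alkene chain and not the change to compound 4. Since compound 1, itself an amide, gives 10400 nM, compound 4 is expected to sit near that weak level, and the step that the limit leaves unreadable from compound 2 to compound 4 is expected to be small or not readable. Compound 4 is therefore estimated at 12000 nM, with a range from 4000 nM to 40000 nM.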

Compound 4, concentration for 50% growth inhibition: > 10000 nM
Compound 4 gave a limit, no number; the forecaster's own chance of this, stated with the estimate: 45%; the middle value does not contradict the limit.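

Compound 4 reaches only a limit in this assay, > 10000 nM. Its steps from compound 1 and from compound 2 therefore cannot be read: the limit of > 10000 nM in this assay, at which 2 of the 4 values shown sit.

The compounds shown leave open whether swapping hydroxy for morpholin-4-yl on the carbonyl carbon changes growth inhibition at all, and by how much compound 2 and compound 4 differ from compound 1.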